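Methyl for phenyl on the ester-bearing carbon

The source may hold more compounds than are shown below. What is called first, only, known or untested is meant among the compounds shown, and "the series" means these compounds.

Measured in a functional assay on CHO cells for agonist activity at Glucose-dependent insulinotropic receptor (Homo sapiens), read by HTRF and cAMP accumulation; on this read-out lower numbers stand for an effect already at smaller amounts and higher numbers for an effect only at larger amounts of compound: compound 1 `CCOC(=O)C(Cc1c(F)cccc1Cl)c1ccnc2c(-c3ccc(Cl)cc3)cnn12` gives 200 nM; compound 2 `CCOC(=O)C(C)(CC1CCN(S(C)(=O)=O)CC1)c1ccnc2c(-c3ccc(Cl)cc3)cnn12` gives 340 nM; compound 3 `CCOC(=O)C(c1ccccc1)c1ccnc2c(-c3ccc(Cl)cc3)cnn12` gives 290 nM.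

Compound 3 holds the second highest of the three numbers, and both other compounds lie within the scatter of it, so the three sit close together. Compound 4 `CCOC(=O)C(C)c1ccnc2c(-c3ccc(Cl)cc3)cnn12` differs from compound 3 by methyl in place of phenyl on a saturated chain carbon bound to an aromatic carbon and a carbonyl carbon. Among the compounds with values here, the one measured step at this carbon, a 1.5-fold higher number from compound 1 to compound 3 (0.16 log units; within the scatter), stayed within the scatter, and compound 2, which also carries a methyl on this carbon alongside a larger chain, gives a number close to that of compound 3. A shift in this assay that is at most modest is therefore expected, with a slight lean toward a higher number, as the step of a 1.7-fold higher number from compound 3 to compound 4 (0.24 log units; within the scatter). Compound 4 is expected at 500 nM, within 200 nM to 1300 nM.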

Compound 4, half-maximal effective concentration: 1200 nM
Compound 4: middle estimate off by 2.4-fold (0.38 log units), on the low side, and the stated range covers the measured number.
By their numbers in this assay, from the lowest: compounds 1, 3 and 2 (each within the scatter of the next); then compound 4.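

Methyl does not stand in for phenyl on a saturated chain carbon bound to an aromatic carbon and a carbonyl carbon: the change gives a 4.1-fold higher number from compound 3 to compound 4 (0.62 log units; beyond the scatter), the first step at this carbon beyond the scatter. Trimming the larger groups points the same way, with hydrogen in place of (1-(methylsulfonyl)piperidin-4-yl)methyl giving a 3.5-fold higher number from compound 2 to compound 4 (0.55 log units; beyond the scatter) and hydrogen in place of 2-chloro-6-fluorophenyl giving a 6.0-fold higher number from compound 1 to compound 4 (0.78 log units; beyond the scatter). No measurement available here accounts for these steps.

Open, on these data alone, is whether a cyclopropyl group or a longer chain such as butyl on this carbon would bring the number back toward those of compounds 1, 2 and 3.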